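Turning the double bond of compound 2 from E to Z

The source may hold more compounds than are shown below. What is called first, only, known or untested is meant among the compounds shown, and "the series" means these compounds.

In a functional assay on HT-29 cells (Homo sapiens) for inhibition (on this read-out lower numbers stand for stronger inhibition and higher numbers for weaker inhibition), compound 2 `O=S(=O)(c1ccccc1)n1ccc2cc(/C=C/c3ccc4ccccc4c3)ccc21` stands at > 5000 nM, which is a limit of the assay and not a number. Its true strength is therefore unknown.

Compound 3 `O=S(=O)(c1ccccc1)n1ccc2cc(/C=C\c3ccc4ccccc4c3)ccc21` has the same atoms and bonds, and only the geometry changes: the two compounds have the same atoms and bonds and differ only in configuration as drawn: 1 of 1 stereo elements differ; a double bond is drawn E in compound 2 and Z in compound 3. Among the measured compounds shown here, no measured pair in this small set shows what such a switch does. For the measured compounds named here, the only guide is compound 1 `COCCOc1cc(/C=C\c2ccc3ccccc3c2)ccc1OC`, which also has its double bond drawn Z and gives 2990 nM in this assay. Its core differs from that of compound 3, so it is a loose guide.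

A modest move towards stronger inhibition is expected, and the estimated step is an at least 2.7-fold lower number from compound 2 to compound 3 (0.44 log units; beyond the scatter). A result that again reaches the limit remains possible. For compound 3 the expected value is 1800 nM, with an estimated range of 200 nM to 6000 nM.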

Compound 3, half-maximal inhibitory concentration: > 5000 nM
Compound 3: no number, only a limit; the forecaster's own chance of this, stated with the estimate: 30%; middle value at least 2.7-fold (0.44 log units) from the limit.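

Compound 3 gives > 5000 nM, which is a limit of the assay and not a number. Compound 2 sits at the same limit, so no step can be read between compound 2 and compound 3: the limit of > 5000 nM in this assay, at which 2 of the 3 values shown sit.

From the compounds shown here alone, whether turning the double bond from E to Z changes the strength of inhibition at all stays open.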